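The source may hold more compounds than are shown below. What is called first, only, known or untested is meant among the compounds shown, and "the series" means these compounds.

Measured so far:
compound 1 `Cc1ccc2c(O)c(C(=O)NCCC(C)C)cnc2n1` — > 10000 nM
compound 2 `Cc1ccc2c(O)c(CC(=O)NCc3ccccc3)cnc2n1` — > 10000 nM
compound 3 `O=C(NCc1ccccc1)c1cnc2nc(Cl)ccc2c1O` — 586 nM

Among the measured compounds shown here, in an assay for binding affinity to adenosine receptor A1 (Bos taurus) (on this read-out lower numbers stand for stronger inhibition and higher numbers for weaker inhibition), compound 3 gives 586 nM, the only actual number among the three entries. For compound 1 the entry is a limit of the assay, not a number. For compound 2 the entry is likewise a limit of the assay. For the measured compounds named here, compounds 1 and 2 thus both sit at the limit of > 10000 nM in this assay, at which 2 of the 3 values shown sit, so compound 3 stands alone as the measured point of the series; no step between two measured compounds that differ in one place is available.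

Compound 4 `CN(C)c1ccc2c(O)c(C(=O)NCc3ccccc3)cnc2n1` is the next to be tested. It differs from compound 3 in one place: dimethylamino in place of chloro on an aromatic carbon. The benzyl amide and the hydroxy group of the shared core are kept.

Going by the values given here, with no measured pair of this kind to lean on, the size of the step in this assay cannot be anchored. A modest shift, most likely toward weaker binding or none beyond the scatter, is expected. Compound 4 is estimated at 1200 nM, with a range from 250 nM to 6000 nM. The step this estimate means is a 2.0-fold higher number from compound 3 to compound 4 (0.31 log units; beyond the scatter), an expectation only.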

Compound 4, inhibition constant: 122 nM
For compound 4 the middle estimate is 9.8-fold (0.99 log units) above the measured one; the measured number lies below the stated range.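

Working notes on the series: in this assay, the series now has its first step between two compounds that differ in one place, and dimethylamino in place of chloro gives a 4.8-fold lower number from compound 3 to compound 4 (0.68 log units; beyond the scatter). This shows that the aromatic carbon next to the ring nitrogen is open to change, as the benzyl amide and the hydroxy group stay the same while the number moves beyond the scatter, and that the entering group, with 3 heavy atoms and 1 hydrogen-bond acceptor, is compatible with a lower number than the single chlorine atom. No measured property available here accounts for the size or direction of this step.

The compounds shown leave open how a primary amine, a methoxy group or diethylamino at this position would read, so the step cannot yet be tied to the nitrogen of dimethylamino or to its heavy-atom count. Also open, going by these compounds, is whether the same change holds with an amide other than the benzyl amide, as both compounds of the step carry that group.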